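The source may hold more compounds than are shown below. What is called first, only, known or untested is meant among the compounds shown, and "the series" means these compounds.

Measured compounds:
compound 1 `COc1ccc(/C=C2\CN(C(=S)SCc3cn(Cc4ccccc4Cl)nn3)C/C(=C\c3ccc(OC)cc3)C2=O)cc1` — > 100000 nM
compound 2 `O=C1/C(=C/c2ccccc2F)CN(C(=S)SCc2cn(Cc3ccccc3Cl)nn2)C/C1=C\c1ccccc1F` — 78700 nM
compound 3 `O=C1/C(=C/c2ccccc2F)CN(Cc2cn(Cc3ccccc3F)nn2)C/C1=C\c1ccccc1F` — 6000 nM

All readings come from a functional assay on MCF7 cells (Homo sapiens) for cytotoxicity, read by MTT assay, with a stated time of 24 h; a higher number here means a weaker inhibitor, a lower number a stronger inhibitor. For compound 1 the reading is not a number but a limit of the assay, > 100000 nM, which is the limit of > 100000 nM in this assay, at which 1 of the 3 values shown sits. Compound 1 therefore stands at the weak end of what this assay can report.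

Compound 4 `COc1ccc(/C=C2\CN(C(=S)SCc3cn(Cc4ccc(F)cc4)nn3)C/C(=C\c3ccc(OC)cc3)C2=O)cc1` differs from compound 1 by 4-fluorophenyl in place of 2-chlorophenyl on a saturated chain carbon bound to an aromatic nitrogen. For the measured compounds named here, no measured pair isolates that change: compound 2 gives 78700 nM and compound 3 gives 6000 nM, but the two differ from each other in more than one place, so their values do not speak to the benzyl substituent alone. The step in this assay is expected to be none beyond the scatter. Compound 4 is expected at 100000 nM, within 40000 nM to 300000 nM, a step of a number no higher from compound 1 to compound 4 (the limit leaves the size open).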

Compound 4, half-maximal inhibitory concentration: > 100000 nM
Compound 4: a limit, no number; the forecaster's own chance of this, stated with the estimate: 50%; the middle value sits exactly at the limit.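

Compound 1 and compound 4 both read as limits of the assay, not numbers, so no step between them can be read: the limit of > 100000 nM in this assay, at which 2 of the 4 values shown sit.

On these data alone, whether 4-fluorophenyl and 2-chlorophenyl differ on the shared core in this assay stays open.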